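The source may hold more compounds than are shown below. What is called first, only, known or untested is meant among the compounds shown, and "the series" means these compounds.

Compounds measured so far:
- compound 1, `COc1cc(/C=C/c2ccc(NC(=O)/C=C/c3cc(OC)c(O)c(OC)c3)cc2)cc(OC)c1`: 3080 nM
- compound 2, `COc1cc(/C=C/c2ccc(NC(=O)/C=C/c3ccc(F)cc3F)cc2)cc(OC)c1`: 18100 nM

In a functional assay on HT-29 cells (Homo sapiens) for inhibition, read by MTT assay, with a stated time of 48 h (on this read-out lower numbers stand for stronger inhibition and higher numbers for weaker inhibition), compound 1 gives 3080 nM, the lowest of the two numbers, and compound 2 gives 18100 nM. For the measured compounds named here, the one step between them, a 5.9-fold higher number from compound 1 to compound 2 (0.77 log units; beyond the scatter), replaces the 4-hydroxy-3,5-dimethoxyphenyl on a double-bonded chain carbon bound to a double-bonded chain carbon with 2,4-difluorophenyl, and the number rises.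

Compound 3, `COc1cc(/C=C/c2ccc(NC(=O)/C=C/c3ccccn3)cc2)cc(OC)c1`, has not yet been measured. It differs from compound 1 as follows: pyridin-2-yl in place of 4-hydroxy-3,5-dimethoxyphenyl on a double-bonded chain carbon bound to a double-bonded chain carbon. Going by the values given here, the only step that bears on this change is the one from compound 1 to compound 2, where the same group at the same place was exchanged for another aromatic ring and the number moved beyond the scatter toward weaker inhibition. A move of similar size and direction in this assay is therefore expected for compound 3, which is an expectation rather than a measurement. Compound 3 is estimated at 12000 nM, with a range from 4000 nM to 36000 nM, and the step this implies from compound 1 is expected to be a 3.9-fold higher number from compound 1 to compound 3 (0.59 log units; beyond the scatter).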

Compound 3, half-maximal inhibitory concentration: 6120 nM
The estimate for compound 3 lay 2.0-fold (0.29 log units) above the measured number; the range from low to high includes it.
By their numbers in this assay, from the lowest: compounds 1 and 3 (each within the scatter of the next); then compound 2.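

In this assay, for the compounds shown here, the pyridin-2-yl of compound 3 does not separate from the 4-hydroxy-3,5-dimethoxyphenyl of compound 1, with a 2.0-fold higher number from compound 1 to compound 3 (0.30 log units; within the scatter), so exchanging the group at this place does not by itself carry the number toward weaker inhibition, as the single earlier step could have suggested. Against the 2,4-difluorophenyl of compound 2, the same pyridin-2-yl gives a 3.0-fold lower number from compound 2 to compound 3 (0.47 log units; beyond the scatter), which leaves compound 2 alone at the high end of the three numbers and shows that the outcome depends on which ring enters, not merely on the loss of the 4-hydroxy-3,5-dimethoxyphenyl. Among these compounds, the hydrogen-bond donor and the larger heavy-atom count of the leaving group are therefore not needed to keep the number in the range of compound 1.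

Nothing measured alongside these numbers accounts for the difference between the rings. From the compounds shown here alone, it remains open whether a pyridin-3-yl, an unsubstituted phenyl or a 4-aminophenyl at this place would fall with compound 1 and compound 3 or with compound 2.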